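Acid dissociation across two aryl ether amines and a third

The source may hold more compounds than are shown below. What is called first, only, known or untested is meant among the compounds shown, and "the series" means these compounds.

Measured so far:
compound 1, `CC(C)N1CCC(Oc2ccc3nc(C(=O)N4CCC4)ccc3c2)CC1` — in a physicochemical assay for acid dissociation, compound 1 gives 9.5
compound 2, `CC1CCN(C(=O)c2ccc3cc(OCCC4CCCN4C)ccc3c2)CC1` — in this assay compound 2 gives 9.9

Compound 2 holds the highest of the two numbers in this assay; its nearest neighbour, compound 1, lies lower by a gap that is beyond the usual scatter. Going by the values given here, no pair of measured compounds differing in a single place is on record, so no measured step is available.

Compound 3, `CC1CCN(C(=O)c2ccc3cc(OC4CCN(C(C)C)CC4)ccc3c2)CC1`, is the next compound to be measured in this assay. Relative to compound 2 the change is 1-isopropylpiperidin-4-yl in place of 2-(1-methylpyrrolidin-2-yl)ethyl on an oxygen on an aromatic ring. The group that enters is the same 1-isopropylpiperidin-4-yl that sits on the oxygen of compound 1, while the amide part of compound 3 is that of compound 2.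

A downward step of a number 0.40 log units lower from compound 2 to compound 3 (beyond the scatter) is expected in this assay, beyond the scatter. The expectation rests on compound 1, because 9.5 is its value with the same group on the oxygen. Compound 3 is therefore estimated at 9.5 in this assay, within a range from 9.1 to 9.9.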

Compound 3, acid dissociation constant: 9.6
Estimate against measurement, compound 3: 0.10 log units below; low and high end bracket the measured number.
By their numbers in this assay, from the lowest: compounds 1, 3 and 2 (each within the scatter of the next, the first and the last beyond it).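

Working notes on the oxygen substituent: the series now has its first step in a single place, and in this assay the exchange of 2-(1-methylpyrrolidin-2-yl)ethyl for 1-isopropylpiperidin-4-yl on an oxygen on an aromatic ring reads as a number 0.30 log units lower from compound 2 to compound 3 (within the scatter) with the amide part unchanged. At this position, then, a group with one five-membered non-aromatic ring and a group with one six-membered non-aromatic ring cannot be told apart in this read-out, and the gap of this one pair does not go beyond what repeated measurements would give. No measurement on hand bears on the reason for this result.

Still open, from the compounds shown here alone, is whether the same exchange would read alike on the amide part of compound 1, as one pair on one amide cannot show how general the step is. Also open, going by these compounds, is how this assay would respond to a different kind of group on this oxygen, such as a longer chain ending in a primary amine, or a chain carrying a carboxylic acid.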